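This account rests on a few compounds, and the source may have more. Where it says the series, first, only, none or still open, it means among the compounds named here.

In a functional assay on DU-145 cells (Homo sapiens) for cytotoxicity, read by trypan blue exclusion, with a stated time of 96 h (on this read-out higher numbers stand for weaker inhibition and lower numbers for stronger inhibition), compound 1 `COc1ccc(NS(=O)(=O)/C=C/c2ccc(OC)cc2OC)cc1` gives 15000 nM, while compound 2 `COc1cc(OC)c(/C=C/S(=O)(=O)Nc2ccc(OC)c(F)c2)c(OC)c1` gives 200 nM, the lower of the two numbers, with a gap to compound 1 that lies well beyond the usual scatter. Compound 3 `COc1cc(OC)c(/C=C/S(=O)(=O)Nc2ccc(OC)c(NCC(=O)O)c2)c(OC)c1` has not yet been measured in this assay. From compound 2 to compound 3 the change is (carboxymethyl)amino in place of fluoro on an aromatic carbon. Within the data shown here, no measured pair shows such a change, so the outcome is uncertain; a step toward weaker inhibition is expected, of about a 7.5-fold higher number from compound 2 to compound 3 (0.88 log units; beyond the scatter). Compound 3 is estimated at 1500 nM, within a range from 300 nM to 8000 nM.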

Compound 3, half-maximal inhibitory concentration: 400 nM
Compound 3: the middle estimate sits 3.8-fold (0.57 log units) above what was measured, and the stated range covers the measured number.
By their numbers in this assay, from the lowest: compounds 2 and 3 (each within the scatter of the next); then compound 1.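

In this assay, putting (carboxymethyl)amino in place of fluoro gives a 2.0-fold higher number from compound 2 to compound 3 (0.30 log units; within the scatter), so compound 2 and compound 3 cannot be told apart here. On this aromatic carbon, ortho to a methoxy group, a group of 5 heavy atoms with 2 hydrogen-bond donors can thus stand where a single fluorine stood without a step beyond the scatter. Nothing available explains this result.

On these data alone, it remains open whether a plain amine on this carbon would give a similar number. As far as these compounds go, it is equally open whether a longer chain ending in a carboxylic acid would.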